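Methoxy on the Phenyl Beside a Trifluoromethyl Ketone

This account rests on a few compounds, and the source may have more. Where it says the series, first, only, none or still open, it means among the compounds named here.

Compound 1 `Nc1ccccc1NC(=O)CCCCCCc1nc(-c2ccccc2)no1`: in an assay on isolated protein for inhibition of histone deacetylase 8 (Homo sapiens), read by fluorescence, with a stated time of 10 min (a lower number here means a stronger inhibitor, a higher number a weaker inhibitor), compound 1 gives > 10000 nM, a limit of the assay rather than a number.
Compound 2 `O=C(CCCCCCc1nc(-c2ccccc2)no1)C(F)(F)F`: in this assay compound 2 gives 760 nM.

Compound 2 therefore holds the only true number shown; compound 1 sits at the limit of > 10000 nM in this assay, at which 1 of the 2 values shown sits. For the measured compounds named here, the one measured step, an at least 13-fold lower number from compound 1 to compound 2 (1.11 log units; beyond the scatter), alters the carbonyl substituent and says nothing about the phenyl. Compound 3 `COc1ccc(-c2noc(CCCCCCC(=O)C(F)(F)F)n2)cc1` differs from compound 2 by methoxy in place of hydrogen on an aromatic carbon. Going by the values given here, no measured step touches that position, so no change beyond the scatter is expected: no change at the digits printed from compound 2 to compound 3 (within the scatter). Compound 3 is estimated at 760 nM, between 300 nM and 2000 nM.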

Compound 3, half-maximal inhibitory concentration: 1860 nM
Estimate against measurement, compound 3: 2.4-fold (0.39 log units) below, within the range that was stated.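

In this assay the change from phenyl to 4-methoxyphenyl gives a 2.4-fold higher number from compound 2 to compound 3 (0.39 log units; beyond the scatter) and so a weaker inhibitor. For the compounds shown here, this is the first reading at the phenyl, as the earlier step altered only the carbonyl substituent, and it shows that this ring position is not indifferent to what sits on it. Nothing shown explains why the number rises.

A single substituent at a single position cannot show a trend. A methyl, a chlorine or a hydroxyl in place of the methoxy would show whether any added group raises the number or methoxy alone does.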